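From Methylsulfonyl to Trifluoromethyl: Estimating Compound 4

A few compounds are considered here, and "the series" means these few. Any claim that something is new, unique, unknown or untested is made for them only; others in the source may bear on it.

Three measured compounds share one core and differ only in the group attached to one nitrogen. Compound 1 `FC(F)(F)c1ccc(Nc2ncnc3sc(Nc4c(Cl)cccc4Cl)nc23)cc1` carries 2,6-dichlorophenyl there, and in a functional assay on HEK293 cells for antagonist activity at transient receptor potential cation channel subfamily V member 1 (Homo sapiens), read by calcium flux (on this read-out lower numbers stand for stronger inhibition and higher numbers for weaker inhibition), compound 1 gives 12 nM. Compound 2 `Cc1cccc(C)c1Nc1nc2c(Nc3ccc(C(F)(F)F)cc3)ncnc2s1` carries 2,6-dimethylphenyl, and in this assay compound 2 gives 23 nM; the step of a 1.9-fold higher number from compound 1 to compound 2 (0.28 log units; within the scatter) stays within the scatter. Compound 3 `CS(=O)(=O)c1ccccc1Nc1nc2c(Nc3ccc(C(F)(F)F)cc3)ncnc2s1` carries 2-(methylsulfonyl)phenyl, and in this assay compound 3 gives 234 nM, the highest number of the three and so the weakest inhibition, as the steps of a 20-fold higher number from compound 1 to compound 3 (1.29 log units; beyond the scatter) and a 10-fold higher number from compound 2 to compound 3 (1.01 log units; beyond the scatter) show.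

Compound 4 `FC(F)(F)c1ccc(Nc2ncnc3sc(Nc4ccccc4C(F)(F)F)nc23)cc1` differs from compound 3 in one place: trifluoromethyl in place of methylsulfonyl on an aromatic carbon. The two large steps into compound 3 both describe methylsulfonyl entering and the number rising sharply. Here methylsulfonyl leaves, so a step back down is expected, though the groups of compounds 1 and 2 are not restored and a single trifluoromethyl enters instead. The step of a 5.9-fold lower number from compound 3 to compound 4 (0.77 log units; beyond the scatter) is therefore expected. Compound 4 is estimated to give 40 nM, within a range from 12 nM to 130 nM.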

Compound 4, half-maximal inhibitory concentration: 74 nM
Compound 4: middle estimate off by 1.9-fold (0.27 log units), on the low side; measured number inside the range.
By their numbers in this assay, from the lowest: compounds 1 and 2 (each within the scatter of the next); then compound 4; then compound 3.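

Putting trifluoromethyl in place of methylsulfonyl recovers only part of the loss in this assay, giving a 3.2-fold lower number from compound 3 to compound 4 (0.50 log units; beyond the scatter). The 2-(trifluoromethyl)phenyl group still falls short of 2,6-dimethylphenyl, with a 3.2-fold higher number from compound 2 to compound 4 (0.51 log units; beyond the scatter), and of 2,6-dichlorophenyl, with a 6.2-fold higher number from compound 1 to compound 4 (0.79 log units; beyond the scatter). Until now this position had shown only two numbers within the scatter of each other and one far higher; compound 4 now lies beyond the scatter from all three, so among these four compounds the group on this nitrogen gives a graded series rather than a simple split into good and poor.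

Nothing measured on these groups bears on why the numbers differ. On these data alone, it also stays open whether a methoxy group or an amine in place of trifluoromethyl would fall nearer compound 1 or nearer compound 3.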